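A few compounds are considered here, and "the series" means these few. Any claim that something is new, unique, unknown or untested is made for them only; others in the source may bear on it.

Three compounds have been measured in an ADME assay on HPC cells (Homo sapiens) for cytotoxicity, with a stated time of 24 h (a higher number here means that more compound is tolerated, a lower number that less compound is tolerated), so far:

- Compound 1 `O=C1/C(=C/c2ccc(Cl)cc2)CCC/C1=C\c1ccccc1[N+](=O)[O-]` gives 400000 nM
- Compound 2 `COc1ccc(/C=C2\CCC/C(=C\c3ccccc3[N+](=O)[O-])C2=O)cc1` gives > 400000 nM (a limit of the assay)
- Compound 3 `O=C1/C(=C/c2ccccc2)CCC/C1=C\c1cccc([N+](=O)[O-])c1` gives 14000 nM

Compound 3 has the lowest number of the three, and the nearest number, that of compound 1, lies higher by more than the usual scatter. Compound 4 `O=C1/C(=C/c2ccc(Cl)cc2)CCC/C1=C\c1cccc([N+](=O)[O-])c1` comes from compound 3 by one change: chloro in place of hydrogen on an aromatic carbon. Going by the values given here, the only measured single change in the set is a number no lower from compound 1 to compound 2 (the limit leaves the size open), which is methoxy in place of chloro on an aromatic carbon. That step ends at the limit of > 400000 nM in this assay, at which 1 of the 3 values shown sits, and so has no readable size. It also does not measure chloro in place of hydrogen, so it gives no direction for the present change. No step beyond the scatter is therefore expected in this assay, and the estimate rests on compound 3 at 14000 nM with a wide margin. The expected step is a 1.1-fold higher number from compound 3 to compound 4 (0.06 log units; within the scatter). For compound 4 the estimated value is 16000 nM, with an expected range of 4000 nM to 70000 nM.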

Compound 4, half-maximal cytotoxic concentration: 18000 nM
Compound 4: middle estimate off by 1.1-fold (0.05 log units), on the low side; the range from low to high includes it.
By their numbers in this assay, from the lowest: compounds 3 and 4 (each within the scatter of the next); then compound 1.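

In this assay the change from phenyl to 4-chlorophenyl gives a 1.3-fold higher number from compound 3 to compound 4 (0.11 log units; within the scatter) and so now has a readable size, one that stays within the scatter. Chloro on this aromatic carbon, para to a large group, therefore does not separate compound 4 from compound 3 in this assay. Compound 1 gives 400000 nM and compound 4 gives 18000 nM with the same 4-chlorophenyl group, the two differing only in where the nitro group sits, and the higher number belongs to compound 1.

From the compounds shown here alone, whether an amine or a carboxylic acid on that aromatic carbon would move the number beyond the scatter stays open. Compound 2 stands at a limit of the assay, so the step to it from compound 1 cannot be read: the limit of > 400000 nM in this assay, at which 1 of the 4 values shown sits.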